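Trading chloro for methyl on a chromone-thioether series

The source may hold more compounds than are shown below. What is called first, only, known or untested is meant among the compounds shown, and "the series" means these compounds.

Compound 1 `Cc1cc(C)nc(SCc2cc(=O)c3cc(Cl)ccc3o2)n1`: in a functional assay on MDA-MB-435S cells (Homo sapiens) for cytotoxicity, read by MTT assay, with a stated time of 72 h (a lower number here means a stronger inhibitor, a higher number a weaker inhibitor), compound 1 gives > 25000 nM, which is a limit of the assay rather than a number.
Compound 2 `O=c1cc(CSc2nc3ccccc3s2)oc2ccc(Cl)cc12`: in this assay compound 2 gives > 25000 nM, again a limit.
Compound 3 `Cc1ccc2oc(CSc3nc(C)cc(C)n3)cc(=O)c2c1`: in this assay compound 3 gives > 25000 nM, also a limit.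

All three values sit at the limit of > 25000 nM in this assay, at which 3 of the 3 values shown sit. Compound 3 differs from compound 1 by methyl in place of chloro on an aromatic carbon, and the resulting step that the two limits leave unreadable from compound 1 to compound 3 cannot be read because both ends are limits. Compound 2 shares the pyrimidine-free side of the molecule with compound 4 `Cc1ccc2oc(CSc3nc4ccccc4s3)cc(=O)c2c1`, while the difference between the cores of compound 1 and compound 2 is not broken down here. Compound 4 differs from compound 2 by methyl in place of chloro on an aromatic carbon, the same change as before. Since compound 1 gave > 25000 nM and compound 3 gave > 25000 nM, the step from compound 2 to compound 4 is expected to be a step that the limit leaves unreadable from compound 2 to compound 4, most likely again unreadable. Compound 4 is therefore estimated at 30000 nM, between 10000 nM and 100000 nM.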

Compound 4, half-maximal inhibitory concentration: > 25000 nM
Compound 4: a limit, no number; the forecaster's own chance of this, stated with the estimate: 85%; the middle value does not contradict the limit.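

Compound 2 and compound 4 both give only a limit, not a number, so no step can be read between them. The compounds shown leave open how strongly any of them acts in this assay, and whether trading chloro for methyl changes that.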